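The compounds below may be only part of what the source reports. "The series", "measured", "known", "first", "only" and "open" are said of these compounds alone.

In a functional assay on RAW264.7 cells (Mus musculus) for inhibition, read by Griess assay, with stated times of 1 h and 24 h (on this read-out higher numbers stand for weaker inhibition and lower numbers for stronger inhibition), compound 1 `CCCCOc1ccc(C(O)C2OC(=O)c3c(OC)cc(OC)cc32)cc1` gives 1800 nM and compound 2 `COCCCCOc1ccc(C(O)C2OC(=O)c3c(OC)cc(OC)cc32)cc1` gives 8210 nM, the higher of the two numbers, which makes compound 2 the weaker inhibitor of this pair. The next compound, compound 3 `COc1cc(OC)c2c(c1)C(C(O)c1ccc(OCc3ccc(F)cc3)cc1)OC2=O`, keeps the shared core and changes the chain on the oxygen on the aromatic ring: 4-fluorophenyl in place of 3-methoxypropyl on a saturated chain carbon bound to an oxygen on an aromatic ring. Read one bond further out, 4-methoxybutyl gives way to 4-fluorobenzyl. Among the measured compounds shown here, only one measured step bears on this change: a 4.6-fold higher number from compound 1 to compound 2 (0.66 log units; beyond the scatter), a modest step beyond the scatter that came with adding a methoxy to the chain. For the measured compounds named here, compound 3 lacks that methoxy, so part of this step may be reversed, although no measured compound yet carries a ring at this place. The expected change is a 2.3-fold lower number from compound 2 to compound 3 (0.37 log units; beyond the scatter), a modest step towards stronger inhibition in this assay. For compound 3 the estimated value is 3500 nM, with an expected range from 1000 nM to 12000 nM.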

Compound 3, half-maximal inhibitory concentration: 760 nM
Compound 3: middle estimate off by 4.6-fold (0.66 log units), on the high side; measured number below the stated range.
By their numbers in this assay, from the lowest: compound 3; then compound 1; then compound 2.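

In this assay the 4-fluorobenzyl group on the oxygen on the aromatic ring gives an 11-fold lower number from compound 2 to compound 3 (1.03 log units; beyond the scatter) and thus shows that this place accepts a ring, not only an open chain. The change also gives a 2.4-fold lower number from compound 1 to compound 3 (0.37 log units; beyond the scatter) when set against the simple chain without the methoxy, so compound 3 does more than undo the loss seen with the 4-methoxybutyl chain. Compound 3 is therefore the strongest inhibitor of the three, and swapping the chain for a ring moves the number further here than adding the methoxy did.

The ring and its fluorine arrive together, so a plain benzyl group or a 4-chlorobenzyl group would be needed to tell their shares apart. Nothing available explains the size of this step.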